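The source may report more compounds than this note shows. Statements on the series, on what has been measured and on what is new or still open speak of the compounds shown alone.

Compound 1 `O=C(Nc1cccc(-c2ccccn2)c1)C(Cl)Cl`: > 50000 nM, a limit
Compound 2 `COc1cccc(-c2cccc(NC(=O)C(Cl)Cl)c2)c1`: 43300 nM
Compound 3 `O=C(Nc1cccc(-c2cccc(C(F)(F)F)c2)c1)C(Cl)Cl`: > 50000 nM, a limit

These three compounds were tested in a functional assay on KB 3-1 cells (Homo sapiens) for cytotoxicity, read by MTT assay, with a stated time of 68 h; a lower number here means a stronger inhibitor, a higher number a weaker inhibitor. In this assay compound 3 gives > 50000 nM, which is a limit and not a number. This is the limit of > 50000 nM in this assay, at which 2 of the 3 values shown sit.

The next compound, compound 4 `O=C(Nc1cccc(-c2cccc(Cl)c2)c1)C(Cl)Cl`, carries one structural change: chloro in place of trifluoromethyl on an aromatic carbon. Going by the values given here, the one measured step that bears on this change is an at least 1.1-fold higher number from compound 2 to compound 3 (0.06 log units; that floor lies within the scatter), with trifluoromethyl in place of methoxy on an aromatic carbon. That swap gave no shift beyond the scatter, so none is expected here in this assay. The estimated step is an at least 1.1-fold lower number from compound 3 to compound 4 (0.07 log units; that floor lies within the scatter). The estimate for compound 4 is 42000 nM, with the value expected to fall from 20000 nM to 70000 nM.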

Compound 4, half-maximal inhibitory concentration: > 50000 nM
Compound 4 gave a limit, no number; the forecaster's own chance of this, stated with the estimate: 50%; middle value at least 1.1-fold (0.07 log units) away from the limit.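

In this assay compound 4 gives a limit, not a number, so the step between compound 3 and compound 4 cannot be read. Chloro in place of methoxy gives an at least 1.1-fold higher number from compound 2 to compound 4 (0.06 log units; that floor lies within the scatter) and so, like trifluoromethyl, shows no shift beyond the scatter at this place, meta to a large group. Compound 4 adds one more compound at the limit: the limit of > 50000 nM in this assay, at which 3 of the 4 values shown sit.

Going by these compounds alone, compound 2 gives 43300 nM as the only true number of the four, and whether an amine or a carboxylic acid at this place would give a clearly lower one stays open.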